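Isopropyl in place of 5-phenylpentyl on the core

The source may report more compounds than this note shows. Statements on the series, on what has been measured and on what is new or still open speak of the compounds shown alone.

- compound 1 `CO[C@@H]1[C@H](OC(=O)NC(=O)CCl)CO[C@]2(COC(C)(C)O2)[C@]1(CCCCCc1ccccc1)OC(=O)NC(=O)CCl` gives 1200 nM as a measured number
- compound 2 `C=C(C)[C@@]1(O)[C@H](OC)[C@H](OC)CO[C@]12CO2` gives > 500000 nM as a limit of the assay

For the measured compounds named here, in a functional assay on A-431 cells (Homo sapiens) for antiproliferative activity (a higher number here means a weaker inhibitor, a lower number a stronger inhibitor), compound 1 holds the only actual number so far (1200 nM) among the measured compounds. Compound 2 gives only a limit of the assay (> 500000 nM) and not a number.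

Compound 3 `CO[C@@H]1[C@H](OC(=O)NC(=O)CCl)CO[C@]2(COC(C)(C)O2)[C@@]1(OC(=O)NC(=O)CCl)C(C)C` keeps the core of compound 1 but carries isopropyl in place of 5-phenylpentyl on a saturated ring carbon and has not yet been measured. Going by the values given here, no measured pair shows what this exchange does, so the expectation is uncertain. A weaker result is expected, meaning a higher number, rather than a change within the scatter. The expected size is a 4.2-fold higher number from compound 1 to compound 3 (0.62 log units; beyond the scatter) as an estimate, and it could prove smaller or larger. Compound 3 is estimated at 5000 nM within an expected range (1200 nM to 30000 nM).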

Compound 3, half-maximal inhibitory concentration: 5600 nM
The estimate for compound 3 lay 1.1-fold (0.05 log units) below the measured number, within the range that was stated.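

For the compounds shown here, on the shared core, isopropyl in place of 5-phenylpentyl on a saturated ring carbon gives a 4.7-fold higher number from compound 1 to compound 3 (0.67 log units; beyond the scatter) in this assay, the first measured reading of a change at this position. The step is modest, and compound 3 still gives an actual number, 5600 nM, so the 5-phenylpentyl group with its aromatic ring is not required for a measurable effect on the shared core. Nothing shown gives a reason for this step.

The compounds shown leave open whether the step follows the length of the chain or the loss of the aromatic ring, and a plain pentyl chain or a 3-phenylpropyl chain on the same carbon would separate the two. Also open, as far as these compounds go, is how an amine or a carboxylic acid at the end of the chain would read here.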